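The source may report more compounds than this note shows. Statements on the series, on what has been measured and on what is new or still open speak of the compounds shown alone.

Compounds measured in an assay on isolated protein for inhibition of Equilibrative nucleoside transporter 1 (Homo sapiens); a higher number here means a weaker inhibitor, a lower number a stronger inhibitor:
- compound 1 `OC[C@H]1O[C@@H](n2cnc3c(SCc4ccccc4I)ncnc32)[C@H](O)[C@@H]1O` gives 19.5 nM
- compound 2 `N#Cc1ccccc1CSc1ncnc2c1ncn2[C@@H]1O[C@H](CO)[C@@H](O)[C@H]1O` gives 38.9 nM
- compound 3 `N#Cc1cccc(CSc2ncnc3c2ncn3[C@@H]2O[C@H](CO)[C@@H](O)[C@H]2O)c1` gives 36.3 nM

All three share one core and differ only in the aromatic group on the saturated chain carbon bound to the sulfur. Compound 2 stands within the scatter of both neighbours in this assay: a 1.1-fold lower number from compound 2 to compound 3 (0.03 log units; within the scatter), and a 2.0-fold higher number from compound 1 to compound 2 (0.30 log units; within the scatter). Likewise a 1.9-fold higher number from compound 1 to compound 3 (0.27 log units; within the scatter). Among the compounds with values here, no step among the measured compounds reaches beyond the scatter.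

Compound 4 `O=[N+]([O-])c1cccc(CSc2ncnc3c2ncn3[C@@H]2O[C@H](CO)[C@@H](O)[C@H]2O)c1` is not yet measured. Its change from compound 2 is 3-nitrophenyl in place of 2-cyanophenyl on a saturated chain carbon bound to a sulfur. Two of the measured steps bear on it. The move of the cyano group from the 2-position to the 3-position is covered by the step from compound 2 to compound 3, which stayed within the scatter. The exchange of one small aromatic substituent for another is covered by the step from compound 1 to compound 2, also within the scatter. Together they suggest no shift in this assay beyond the scatter for the combined change, in either direction.

Compound 4 is therefore expected at about 35 nM in this assay, within 15 nM to 90 nM, an estimated step of a 1.1-fold lower number from compound 2 to compound 4 (0.05 log units; within the scatter).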

Compound 4, inhibition constant: 1.78 nM
For compound 4 the middle estimate is 20-fold (1.29 log units) above the measured one, outside the stated range (below it).
By their numbers in this assay, from the lowest: compound 4; then compounds 1, 3 and 2 (each within the scatter of the next).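

In this assay, the aromatic group on a saturated chain carbon bound to a sulfur turns out to be a sensitive place, although every earlier step among compounds 1, 2 and 3 stayed within the scatter. The most direct reading is nitro in place of cyano on an aromatic carbon, with a 20-fold lower number from compound 3 to compound 4 (1.31 log units; beyond the scatter) at an otherwise unchanged 3-substituted phenyl, so a change of substituent alone, with no move on the ring, is enough for a large step. The 3-nitrophenyl group also stands apart from both 2-substituted groups, with a 22-fold lower number from compound 2 to compound 4 (1.34 log units; beyond the scatter) and an 11-fold lower number from compound 1 to compound 4 (1.04 log units; beyond the scatter) as large steps, which makes compound 4 the strongest inhibitor of the four, and nothing shown here offers an explanation for this gap.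

Within the data shown here, still open is whether the large step belongs to the nitro group alone or depends on where it sits on the phenyl ring, since compound 4 is the only nitro compound in the set. From the compounds shown here alone, it is also open how far this behaviour extends to other substituents in the same place on the phenyl ring, such as an amine, a carboxylic acid or a methyl ester.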